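This account rests on a few compounds, and the source may have more. Where it says the series, first, only, none or still open, it means among the compounds named here.

Two compounds from this study share a core in which a benzyloxy-bearing benzoyl group is joined through a urea or thiourea linker to an aryl unit. Compound 1 `Cc1ccc(NC(=S)NC(=O)c2ccc(OCc3ccccc3)cc2)cc1-c1nc2ccccc2[nH]1` carries the thiourea linker, and compound 2 `Cc1ccc(NC(=O)NC(=O)c2ccc(OCc3ccccc3)cc2)cc1-c1nc2ccccc2[nH]1` the urea. In a functional assay on MNK45 cells (Homo sapiens) for inhibition, read by MTT assay, with a stated time of 48 h (on this read-out higher numbers stand for weaker inhibition and lower numbers for stronger inhibition), compound 1 gives 57800 nM, while compound 2 gives 35100 nM. Compound 2 thus holds the lower of the two numbers, but its gap to compound 1 is within the scatter, so nothing more can be said about their order.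

Compound 3 `Cc1ccc(NC(=O)NC(=O)c2ccc(OCc3ccc(Cl)cc3Cl)cc2)cc1-c1nc2ccccc2[nH]1` differs from compound 2 in one place: 2,4-dichlorophenyl in place of phenyl on a saturated chain carbon bound to an oxygen on an aromatic ring. Going by the values given here, no measured pair in this set shows the effect of such a change, so there is no step to lean on. The account therefore expects only a small movement for compound 3, and the step of a 1.3-fold lower number from compound 2 to compound 3 (0.10 log units; within the scatter) it anticipates stays inside the scatter. On that basis compound 3 is estimated at 28000 nM in this assay, with a range from 9000 nM to 90000 nM.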

Compound 3, half-maximal inhibitory concentration: 2550 nM
Estimate against measurement, compound 3: 11-fold (1.04 log units) above; the whole stated range lies above it.
By their numbers in this assay, from the lowest: compound 3; then compounds 2 and 1 (each within the scatter of the next).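

The position on a saturated chain carbon bound to an oxygen on an aromatic ring proves sensitive in this assay: 2,4-dichlorophenyl in place of phenyl gives a 14-fold lower number from compound 2 to compound 3 (1.14 log units; beyond the scatter). Going by these compounds alone, this is the first step in the set to lie beyond the scatter, as the earlier compounds offered only a change of linker, with their values within the scatter of each other, and both carried the same phenyl at this position. The set contains no measurement that accounts for the size of this step, so its cause remains unknown.

The compounds shown leave open whether this step depends on both chlorine atoms together or whether a phenyl carrying a single chlorine would do the same, and whether a methoxy or trifluoromethyl group on that phenyl would move the number in the same direction. They also leave open whether the thiourea linker of compound 1 would show a step of similar size with the same 2,4-dichlorophenyl group.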